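From thiophen-3-yl to thiophen-2-yl on compound 1

The compounds below may be only part of what the source reports. "The series", "measured", "known", "first", "only" and "open" are said of these compounds alone.

Measured so far in a functional assay on cells (Melanoma cell, Homo sapiens) for inhibition; a higher number here means a weaker inhibitor of growth, a lower number a stronger inhibitor of growth:
compound 1 `Cc1cn2c(/C=N/NC(=N)N)c(-c3ccsc3)nc2s1`: 8130 nM
compound 2 `N=C(N)N/N=C/c1c(-c2ccsc2)nc2sccn12`: 17000 nM
compound 3 `Cc1cc(-c2nc3sccn3c2/C=N/NC(=N)N)c(C)s1`: 16200 nM

Compound 1 stands at 8130 nM, and the value of compound 3 lies within the scatter of it. Hydrogen in place of methyl on an aromatic carbon gives a modest move just beyond the scatter: a 2.1-fold higher number from compound 1 to compound 2 (0.32 log units; beyond the scatter).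

Compound 4 `Cc1cn2c(/C=N/NC(=N)N)c(-c3cccs3)nc2s1` has not yet been measured. It has the same atoms as compound 1, joined differently: thiophen-2-yl in place of thiophen-3-yl on an aromatic carbon. In words, thiophen-2-yl stands in place of thiophen-3-yl on an aromatic carbon. The methyl stays, so the step above does not speak directly to this change. Among the compounds with values here, no measured step moves the point of attachment of the thiophene. The closest evidence is a change to the group at the same place, 2,5-dimethylthiophen-3-yl in place of thiophen-3-yl, which gave a 1.0-fold lower number from compound 2 to compound 3 (0.02 log units; within the scatter). On that single step, no shift beyond the scatter is expected in this assay, and no direction is favoured. The expected step is a 1.0-fold higher number from compound 1 to compound 4 (0.02 log units; within the scatter). Compound 4 is estimated at 8500 nM, with an expected range from 3500 nM to 20000 nM.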

Compound 4, concentration for 50% growth inhibition: 2240 nM
The estimate for compound 4 lay 3.8-fold (0.58 log units) above the measured number; the whole stated range lies above it.
By their numbers in this assay, from the lowest: compound 4; then compounds 1, 3 and 2 (each within the scatter of the next, the first and the last beyond it).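

In this assay, the position on the core that carries the thiophene proves sensitive to where that ring is attached: with the same atoms and the same counts of donors and acceptors in the group, thiophen-2-yl in place of thiophen-3-yl gives a 3.6-fold lower number from compound 1 to compound 4 (0.56 log units; beyond the scatter). Within the data shown here, the only earlier change at this place, 2,5-dimethylthiophen-3-yl in place of thiophen-3-yl on the core without the methyl, stayed within the scatter, with a 1.0-fold lower number from compound 2 to compound 3 (0.02 log units; within the scatter), so that step had given no sign that this position could move the number at all. Nothing available here accounts for the shift, so the result stands as an observation about the point of attachment and offers no explanation.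

As far as these compounds go, whether the same move would lower the number on the core of compound 2, which carries hydrogen in place of the methyl, remains open. Also open, from the compounds shown here alone, is whether the lower number belongs to thiophen-2-yl in particular or would also appear with furan-2-yl, a phenyl ring or a 5-methylthiophen-2-yl group at this place.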